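Benzylamide series: loss of the phenyl substituent

The source may report more compounds than this note shows. Statements on the series, on what has been measured and on what is new or still open speak of the compounds shown alone.

Measured compounds:
compound 1 `CC(C)(C)[C@@H](N)C(=O)NCc1ccc(OC(F)(F)F)cc1`: 23 mg/kg
compound 2 `CC(C)(C)[C@@H](N)C(=O)NCc1ccc(-c2ccccc2)cc1`: "not determined" (no result reported)

Compound 1 `CC(C)(C)[C@@H](N)C(=O)NCc1ccc(OC(F)(F)F)cc1` is the only measured anchor; in a functional assay on the whole organism (strain albino Sprague-Dawley) with Rattus norvegicus as the target, in the maximal electroshock model (on this read-out lower numbers stand for an effect already at smaller amounts and higher numbers for an effect only at larger amounts of compound), compound 1 gives 23 mg/kg. Within the data shown here, compound 2 `CC(C)(C)[C@@H](N)C(=O)NCc1ccc(-c2ccccc2)cc1` carries a phenyl where compound 1 carries trifluoromethoxy, but in this assay compound 2 gives "not determined" (no result reported), so compound 2 stands nowhere on the scale and the series holds no single step between measured compounds. Compound 3 `CC(C)(C)[C@@H](N)C(=O)NCc1ccccc1` differs from compound 2 by hydrogen in place of phenyl on an aromatic carbon. Without a measured pair, the size of the step from compound 2 to compound 3 in this assay cannot be read from data; a moderate move toward higher numbers is expected, though a step within the scatter is equally plausible. For compound 3 a value of 45 mg/kg is expected in this assay, with a range from 15 mg/kg to 150 mg/kg, resting on compound 1 at 23 mg/kg as the nearest measured point.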

Compound 3, dose for half-maximal effect: 11 mg/kg
Compound 3: middle estimate off by 4.1-fold (0.61 log units), on the high side, outside the stated range (below it).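

In this assay the series gains its first readable step: hydrogen in place of trifluoromethoxy on the aromatic carbon gives a 2.1-fold lower number from compound 1 to compound 3 (0.32 log units; beyond the scatter). This position therefore carries no need for a substituent in this read-out, as compound 3, with only hydrogen there, sits lower on the scale than compound 1 with trifluoromethoxy. Nothing at hand explains this step.

Compound 2 has no result, so the step from compound 2 to compound 3 cannot be read and phenyl at this position remains unplaced on the scale. From the compounds shown here alone, with one step, it also stays open whether fluorine, a methoxy group or an amine on the same carbon would stand with compound 3 or with compound 1.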